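Sulfamoyl Exchanged for Methanesulfonamido on a Dopamine Transporter Scaffold

The source may hold more compounds than are shown below. What is called first, only, known or untested is meant among the compounds shown, and "the series" means these compounds.

Compound 1 `CC(c1ccc(Cl)c(Cl)c1)c1ccccc1CN(C)C` in an assay on HEK293 cells for inhibition of sodium-dependent dopamine transporter (Homo sapiens); on this read-out lower numbers stand for stronger inhibition and higher numbers for weaker inhibition: "not determined" (no result reported)
Compound 2 `CN(C)Cc1ccccc1Oc1ccc(C#N)cc1` in this assay: "not determined" (no result reported)
Compound 3 `CN(C)Cc1cc(S(N)(=O)=O)ccc1Sc1ccc(C(F)(F)F)cc1` in this assay: > 10000 nM

Only compound 3 carries a result at all, and that result is a limit of this assay rather than a number: compound 3 sits at the limit of > 10000 nM in this assay, at which 1 of the 3 values shown sits. For the measured compounds named here, compound 1 and compound 2 offer nothing to set beside it, so no step between measured compounds exists and no size of change can be read from the data. Compound 4, `CN(C)Cc1cc(NS(C)(=O)=O)ccc1Sc1ccc(C(F)(F)F)cc1`, differs from compound 3 in one place: methanesulfonamido in place of sulfamoyl on an aromatic carbon. Without a measured step to lean on, compound 4 is expected to stay weak in this assay, with an estimated value of 12000 nM in a range from 2500 nM to 60000 nM. The estimated change is a step that the limit leaves unreadable from compound 3 to compound 4, no more than the usual scatter.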

Compound 4, half-maximal inhibitory concentration: 6900 nM
The estimate for compound 4 lay 1.7-fold (0.24 log units) above the measured number; the measured number falls inside the stated range.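

For the compounds shown here, compound 4 gives the only actual number at this position in this assay, so methanesulfonamido in place of sulfamoyl on an aromatic carbon yields a value rather than a limit. Going by these compounds alone, the exchange gives an at least 1.4-fold lower number from compound 3 to compound 4 (0.16 log units; that floor lies within the scatter) as its only readable step. Compound 3 holds a limit of the assay and not a number, so that step is only a floor and its true size stays unknown: the limit of > 10000 nM in this assay, at which 1 of the 4 values shown sits.

On these data alone, whether an amine or a carboxylic acid at this place would give a lower number stays open. So does the effect of a longer chain on the sulfonyl group, such as ethanesulfonamido.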